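This account rests on a few compounds, and the source may have more. Where it says the series, first, only, none or still open, it means among the compounds named here.

Working notes on the series. Compound 1 `C#Cc1cn([C@@H]2O[C@H](CO)[C@@H](O)[C@H]2O)c2ncnc(C)c12` carries an ethynyl group on the shared core, and in a functional assay on HeLa S3 cells (Homo sapiens) for antiproliferative activity, read by XTT assay, with a stated time of 72 h (a lower number here means a stronger inhibitor, a higher number a weaker inhibitor), compound 1 gives 14700 nM. Compound 2 `Cc1ncnc2c1c(-c1ccoc1)cn2[C@@H]1O[C@H](CO)[C@@H](O)[C@H]1O` differs from compound 1 by furan-3-yl in place of ethynyl on an aromatic carbon. In this assay compound 2 reaches only the limit of the assay, > 20000 nM. The step of an at least 1.3-fold higher number from compound 1 to compound 2 (0.13 log units; that floor lies within the scatter) therefore has a floor and no fixed size.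

Compound 3 `C#Cc1cn([C@@H]2O[C@H](CO)[C@@H](O)[C@H]2O)c2nc(N)nc(OC)c12` has a different core; the difference between the two cores is not broken down here. In this assay compound 3 also gives only a limit, > 20000 nM. Compound 4 `COc1nc(N)nc2c1c(-c1ccoc1)cn2[C@@H]1O[C@H](CO)[C@@H](O)[C@H]1O` is not yet measured; it differs from compound 3 by furan-3-yl in place of ethynyl on an aromatic carbon, the same change as that from compound 1 to compound 2, at a place described in the same words.

A weak series overall: the limit of > 20000 nM in this assay, at which 2 of the 3 values shown sit. With compound 3 already at the limit and the earlier change going no stronger, the step that the limit leaves unreadable from compound 3 to compound 4 is expected. Compound 4 is estimated at 30000 nM in this assay, most likely reported only as a limit, within 15000 nM to 80000 nM.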

Compound 4, half-maximal inhibitory concentration: > 20000 nM
Compound 4 was reported as a limit (the forecaster's own chance of this, stated with the estimate: 90%); the middle value lies beyond the limit too.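

In this assay compound 4 gives > 20000 nM, a limit of the assay. Compound 3 is also a limit, so no step can be read between compound 3 and compound 4. The compounds shown leave open what size of effect, if any, furan-3-yl in place of ethynyl has on the core of compound 3: the limit of > 20000 nM in this assay, at which 3 of the 4 values shown sit.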